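A few compounds are considered here, and "the series" means these few. Any claim that something is new, unique, unknown or untested is made for them only; others in the source may bear on it.

Compound 1 `CCn1c(-c2cnc(C)nc2)nc2c(N[C@H]3CCN(C(=O)C4CC(F)(F)C4)C3)ncnc21` gives 0.4 h in an ADME assay (Rattus norvegicus, strain Wistar Han) for metabolic stability (a lower number here means that the compound disappears faster, a higher number that the compound lasts longer), and stands lowest of the three measured numbers; compound 3 `CCn1c(-c2ccc(C(F)(F)F)nc2)nc2c(O[C@H]3CCN(C(=O)[C@H]4C[C@@H](OC)C4)C3)ncnc21` gives 3.3 h and compound 2 `CCn1c(-c2ccc(C(F)(F)F)nc2)nc2c(O[C@H]3CCN(C(=O)c4cocn4)C3)ncnc21` gives 6 h. Among the compounds with values here, the only measured step, a 1.8-fold lower number from compound 2 to compound 3 (0.26 log units; within the scatter), swaps the group on the carbonyl carbon within the core of compound 2 and stays within the scatter. Compound 4 `CCn1c(-c2cnc(C)nc2)nc2c(N[C@H]3CCN(C(=O)N4CC(OC)C4)C3)ncnc21` differs from compound 1 as 3-methoxyazetidin-1-yl in place of 3,3-difluorocyclobutyl on a carbonyl carbon. Within the data shown here, no measured step touches the core of compound 1 directly; the one step on a carbonyl substituent, on another core, was small. A small rise at most is therefore expected, a 1.8-fold higher number from compound 1 to compound 4 (0.24 log units; within the scatter), with the result for compound 4 estimated at 0.7 h (range 0.3 h to 1.8 h).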

Compound 4, half-life: 4 h
Compound 4: the middle estimate sits 5.7-fold (0.76 log units) below what was measured; measured number outside the range, above it.
By their numbers in this assay, from the lowest: compound 1; then compounds 3, 4 and 2 (each within the scatter of the next).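

Within the data shown here, on the carbonyl carbon in the core of compound 1, 3-methoxyazetidin-1-yl in place of 3,3-difluorocyclobutyl gives a 10-fold higher number from compound 1 to compound 4 (1.00 log units; beyond the scatter) in this assay, so this position can shift the half-life beyond the scatter, unlike the one earlier step on a carbonyl substituent. The change swaps two fluorine atoms for a methoxy oxygen and brings in a ring nitrogen, and this single pair cannot separate the two. No measurement on hand accounts for the step. Unsubstituted azetidin-1-yl and 3,3-difluoroazetidin-1-yl on the same core would tell the ring nitrogen from the methoxy group.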